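Hexyl Gives Way to 2-(Trifluoromethyl)phenyl on the Triazole

A few compounds are considered here, and "the series" means these few. Any claim that something is new, unique, unknown or untested is made for them only; others in the source may bear on it.

Among the measured compounds shown here, compound 2 `CCCCCCc1cn(C(c2ccccc2)c2cc3cc(Br)ccc3nc2OC)nn1` stands lowest of the two numbers measured so far in an ADME assay on HEK293 cells (Homo sapiens) for cytotoxicity, read by sulforhodamine B assay, with a stated time of 48 h, tested at 10 uM (a higher number here means more inhibition at the concentration tested (going by the name of the read-out), a lower number less inhibition), where compound 2 gives -3.17%. For the measured compounds named here, its nearest neighbour, compound 1 `COc1nc2ccc(Br)cc2cc1C(c1ccccc1)n1cc(CCCCCO)nn1`, gives 7.96% in this assay, and the single measured step, a number 11.1 percentage points lower from compound 1 to compound 2 (beyond the scatter), concerns hydroxy giving way to methyl on the chain. Compound 3 `COc1nc2ccc(Br)cc2cc1C(c1ccccc1)n1cc(-c2ccccc2C(F)(F)F)nn1` differs from compound 2 in one place: 2-(trifluoromethyl)phenyl in place of hexyl on an aromatic carbon. Going by the values given here, no measured step concerns an exchange of this kind; the only step recorded is of modest size and offers no direct guide to hexyl being replaced by 2-(trifluoromethyl)phenyl. On that footing compound 3 is expected to show only a small step, a number 8.2 percentage points higher from compound 2 to compound 3 (within the scatter), with its direction uncertain. Compound 3 is therefore estimated at 5% in this assay, within a range from -10% to 20%.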

Compound 3, a percentage reported as inhibition, at one concentration (the size of the read-out at that concentration, not a potency): 14.3%
For compound 3 the middle estimate is 9.3 percentage points below the measured one, and the stated range covers the measured number.
By their numbers in this assay, from the lowest: compound 2; then compounds 1 and 3 (each within the scatter of the next).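

In this assay this aromatic carbon of the five-membered ring carries a ring as well as a chain, and exchanging the whole group, not just the chain end, gives a number 17.5 percentage points higher from compound 2 to compound 3 (beyond the scatter) in a step of modest size. Set against 5-hydroxypentyl, the same 2-(trifluoromethyl)phenyl gives a number 6.3 percentage points higher from compound 1 to compound 3 (within the scatter) and so cannot be told apart from it here, although only the chain ends in hydroxy. No independent measurement accounts for either step.

The compounds shown leave open whether plain phenyl, a pyridine ring, or a chain ending in an amine or a carboxylic acid would behave like either group at this carbon. They also leave open how these single-concentration numbers would translate into a potency.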